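Acetamido in place of the furan-2-yl carbonyloxy group

The source may hold more compounds than are shown below. What is called first, only, known or untested is meant among the compounds shown, and "the series" means these compounds.

In an ADME assay on cells (Hepatocyte, Mus musculus) for metabolic stability (a lower number here means that the compound disappears faster, a higher number that the compound lasts longer), compound 3 `O=C(OC1CCC(CN2CCN(c3cc(=O)c4cc(C(F)(F)F)cc([N+](=O)[O-])c4s3)CC2)CC1)c1ccco1` is known only as a limit, < 0.075 h. Compound 2 `CC(=O)OC1CCC(CN2CCN(c3cc(=O)c4cc(C(F)(F)F)cc([N+](=O)[O-])c4s3)CC2)CC1` is also a limit, < 0.15 h. Compound 1 `O=c1cc(N2CCN(CC3CCC(NS(=O)(=O)c4ccccc4)CC3)CC2)sc2c([N+](=O)[O-])cc(C(F)(F)F)cc12` is a limit too, > 1.55 h. The last two limits at the low end leave a step that the two limits leave unreadable from compound 2 to compound 3.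

Compound 4 `CC(=O)NC1CCC(CN2CCN(c3cc(=O)c4cc(C(F)(F)F)cc([N+](=O)[O-])c4s3)CC2)CC1` brings this change: acetamido in place of ((furan-2-yl)carbonyl)oxy on a saturated ring carbon. Acetamido is joined to the ring carbon through an amino link, as in compound 1, whereas compounds 2 and 3 carry an oxy link there.

For the measured compounds named here, two measured steps bear on this change: an at least 10-fold lower number from compound 1 to compound 2 (1.01 log units; beyond the scatter) and an at least 20-fold lower number from compound 1 to compound 3 (1.31 log units; beyond the scatter). Both are large and beyond the scatter, and both lead to a shorter half-life. Compound 4 keeps the amino link of compound 1 but lacks its phenylsulfonyl group, so a large rise is expected, possibly short of the full reversal of those steps. The expected change is an at least 13-fold higher number from compound 3 to compound 4 (1.12 log units; beyond the scatter). For compound 4 the estimated half-life is 1 h, with an expected range from 0.3 h to 3 h.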

Compound 4, half-life: > 1.55 h
Compound 4 ended at the assay's limit (the forecaster's own chance of this, stated with the estimate: 35%); at least 1.5-fold (0.19 log units) between middle value and limit.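

In this assay, acetamido in place of ((furan-2-yl)carbonyl)oxy gives an at least 20-fold higher number from compound 3 to compound 4 (1.31 log units; beyond the scatter), and acetamido in place of acetoxy gives an at least 10-fold higher number from compound 2 to compound 4 (1.01 log units; beyond the scatter). With acetyl in place of phenylsulfonyl on the amine nitrogen, compound 4 is still known only as a limit, > 1.55 h. The phenylsulfonyl group of compound 1 is therefore not required to reach the upper limit on this saturated ring carbon, and among these four compounds the amino link goes with the upper limit and the oxy link with the lower limits: the limit of > 1.55 h in this assay, at which 2 of the 4 values shown sit.

The steps with a limit at both ends cannot be read, so compound 1 and compound 4 cannot be placed in order. From the compounds shown here alone, whether a free amine or a urea on the same ring carbon would also reach the upper limit remains open.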